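Nitrophenyl for Nitrophenoxy: Expected Tolerance of Compound 3

The source may hold more compounds than are shown below. What is called first, only, known or untested is meant among the compounds shown, and "the series" means these compounds.

Compound 1, `CC1CCN(Cc2nc(SCc3ccc(C#N)cc3)[nH]c(=O)c2I)CC1`, in an ADME assay on HepG2 2.2.15 cells (Homo sapiens) for cytotoxicity, read by MTT assay, with a stated time of 72 h (a higher number here means that more compound is tolerated, a lower number that less compound is tolerated), returns only a limit, > 100000 nM.
Compound 2, `Cc1cc(C)cc(Cc2nc(SCCOc3ccc([N+](=O)[O-])cc3)[nH]c(=O)c2I)c1`, in this assay gives 96600 nM.

Of the compounds shown here, two have been measured in this assay. For compound 1 the assay reports a limit rather than a number, (the limit of > 100000 nM in this assay, at which 1 of the 2 values shown sits). Among the measured compounds shown here, compound 2 therefore stands as the only compound with an actual number in this assay, and that number sits close to where the limit of compound 1 lies, so the two values together show that both compounds are tolerated up to the high end of what the assay covers.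

The next compound, compound 3, is `Cc1cc(C)cc(Cc2nc(SCCc3ccc([N+](=O)[O-])cc3)[nH]c(=O)c2I)c1`. It is derived from compound 2 by a single change: 4-nitrophenyl in place of 4-nitrophenoxy on a saturated chain carbon, two bonds along the chain from a sulfur. No measured step of this kind exists among the shown compounds. Given that compound 2 gives 96600 nM, the expectation for this assay is a step of no size beyond the usual scatter, a 1.0-fold higher number from compound 2 to compound 3 (0.02 log units; within the scatter). Compound 3 is thus estimated at 100000 nM, with a range from 50000 nM to 200000 nM.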

Compound 3, half-maximal cytotoxic concentration: 66600 nM
For compound 3 the middle estimate is 1.5-fold (0.18 log units) above the measured one, within the range that was stated.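

The exchange of 4-nitrophenoxy, with 10 heavy atoms, for 4-nitrophenyl, with 9, gives in this assay a 1.5-fold lower number from compound 2 to compound 3 (0.16 log units; within the scatter). Among the compounds shown here, this is the first measured step on a saturated chain carbon, two bonds along the chain from a sulfur, and it shows that this change does not separate the two compounds beyond the usual variation between repeats. Tolerance therefore stays at the high end of the read-out with either group in this place, a region where one of the shown values is only a limit: the limit of > 100000 nM in this assay, at which 1 of the 3 values shown sits.

With a single step, the compounds shown say nothing about how other groups would behave in this place, such as a longer chain, an amine or a carboxylic acid at the end of the chain. They also leave open whether the same exchange would read the same way with the other groups of compound 1 on the shared core, and whether any group here could bring tolerance down by a step beyond the scatter.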